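A few compounds are considered here, and "the series" means these few. Any claim that something is new, unique, unknown or untested is made for them only; others in the source may bear on it.

Measured compounds in an ADME assay on cells (Homo sapiens) for cytotoxicity, read by polymerase chain reaction, with a stated time of 3 days; on this read-out lower numbers stand for higher toxicity in this test and higher numbers for lower toxicity in this test:
compound 1, `CNc1ccc2nc(-c3c(Cl)nc(N)nc3N[C@@H]3C[C@H](CO)[C@@H](O)[C@H]3O)sc2c1`, 6000 nM
compound 2, `Nc1ncc(-c2nc3ccccc3s2)c(N[C@@H]2C[C@H](CO)[C@@H](O)[C@H]2O)n1`; its value is a limit of the assay, > 25000 nM
compound 3, `Cc1nc(N)nc(N[C@@H]2C[C@H](CO)[C@@H](O)[C@H]2O)c1-c1nc2ccccc2s1`, 4000 nM

Compound 3 holds the lower of the two actual numbers; compound 1 stands nearest, and the gap between them is within the scatter, so no order between compound 3 and compound 1 can be read. Compound 2 gives only a limit (the limit of > 25000 nM in this assay, at which 1 of the 3 values shown sits). Going by the values given here, the one step among measured pairs, an at least 6.2-fold lower number from compound 2 to compound 3 (0.79 log units; beyond the scatter), concerns methyl in place of hydrogen on an aromatic carbon.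

Compound 4, `Cc1nc(NCCCC(F)(F)F)nc(N[C@@H]2C[C@H](CO)[C@@H](O)[C@H]2O)c1-c1nc2ccccc2s1`, is not yet measured. It differs from compound 3 by 4,4,4-trifluorobutyl in place of hydrogen on a nitrogen on an aromatic ring. Among the compounds with values here, no measured pair changes the substitution on this nitrogen; that single measured step sits at a different position and gives no direct guide, beyond showing that one small change can move the number beyond the scatter. Within the data shown here, with no precedent on this nitrogen, the expectation for compound 4 is held close to compound 3, a lower number somewhat more likely than a higher one, and the step is expected to be a 1.6-fold lower number from compound 3 to compound 4 (0.20 log units; within the scatter). In this assay compound 4 is therefore estimated at 2500 nM, with a range from 800 nM to 8000 nM.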

Compound 4, half-maximal cytotoxic concentration: 3000 nM
Estimate against measurement, compound 4: 1.2-fold (0.08 log units) below, and the stated range covers the measured number.
By their numbers in this assay, from the lowest: compounds 4, 3 and 1 (each within the scatter of the next). At a limit, above all of these: compound 2.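

In this assay, the amino group on the shared core now has its first measured substitution, and the step reads a 1.3-fold lower number from compound 3 to compound 4 (0.12 log units; within the scatter). A chain of 7 heavy atoms, 4,4,4-trifluorobutyl, can therefore stand in place of hydrogen on a nitrogen on an aromatic ring without separating compound 4 from compound 3 on this read-out, whereas the much smaller replacement at the aromatic carbon gave an at least 6.2-fold lower number from compound 2 to compound 3 (0.79 log units; beyond the scatter). Nothing shown here gives a reason for either outcome, and no measured property bears on the result.

As far as these compounds go, one chain on this nitrogen does not define the position, so it remains open whether an ethyl group, a longer chain, a terminal carboxylic acid or a terminal amine would also leave the number within the scatter of compound 3. Also open, from the compounds shown here alone, is whether 4,4,4-trifluorobutyl would behave the same way on the core of compound 2, whose > 25000 nM is a limit, or on the core of compound 1.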